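A few compounds are considered here, and "the series" means these few. Any claim that something is new, unique, unknown or untested is made for them only; others in the source may bear on it.

Measured so far:
compound 1, `COCOc1cc(/C=C/C(=O)OCC(=O)NN2CCOCC2)ccc1OCc1ccccc1`: > 200000 nM
compound 2, `COc1ccc(/C=C/C(=O)OCC(=O)Nc2ccccc2)cc1OC`: > 200000 nM

In a functional assay on PC-3 cells (Homo sapiens) for cytotoxicity, read by MTT assay, with a stated time of 72 h (a higher number here means a weaker inhibitor, a lower number a stronger inhibitor), compound 2 gives > 200000 nM, which is a limit of the assay and not a number. Compound 1 gives > 200000 nM in this assay, and that too is a limit. So compound 2 does not stand above or below any other compound here: every value shown sits at the same limit, as the limit of > 200000 nM in this assay, at which 2 of the 2 values shown sit, records, and no step between measured compounds can be read off.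

The next compound, compound 3, `COc1ccc(/C=C/C(=O)OCC(=O)Nc2ccc(Cl)cc2)cc1OC`, differs from compound 2 in one place only: chloro in place of hydrogen on an aromatic carbon, the chloro entering para to a large group. Nothing measured here tells how such a change shifts the read-out, and with both known values resting at a limit there is no anchor for a direction. The expected step that the limit leaves unreadable from compound 2 to compound 3 is therefore none beyond the usual scatter. Compound 3 is expected near 250000 nM, within 100000 nM to 600000 nM, most likely reported again only as a limit rather than a number.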

Compound 3, half-maximal inhibitory concentration: > 200000 nM
Compound 3 was reported as a limit; the forecaster's own chance of this, stated with the estimate: 85%; the middle value is on the limit's open side.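

No step can be read from compound 2 to compound 3, where chloro takes the place of hydrogen on an aromatic carbon, because both values are limits and not numbers: the limit of > 200000 nM in this assay, at which 3 of the 3 values shown sit. The compounds shown leave open whether any of them has a measurable value in this assay and how the chloro shifts it.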